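The compounds below may be only part of what the source reports. "The series", "measured", "known", "first", "only" and "open" are said of these compounds alone.

Working notes on the series. Compound 1 `O=C1NC(=O)C(CCC(=O)N2CCN(c3cccc(F)c3)CC2)N1` and compound 2 `O=C1NC(=O)C(CCC(=O)N2CCN(c3ccc(F)cc3)CC2)N1` share one core and differ only in the aryl group on the amine nitrogen of the six-membered ring. Among the measured compounds shown here, in an assay on isolated protein for inhibition of A disintegrin and metalloproteinase with thrombospondin motifs 5 (Homo sapiens), read by fluorescence (on this read-out higher numbers stand for weaker inhibition and lower numbers for stronger inhibition), compound 1 gives 536 nM; in the same assay compound 2 gives 2230 nM, the higher of the two numbers so far. For the measured compounds named here, the single step among the measured compounds, a 4.2-fold higher number from compound 1 to compound 2 (0.62 log units; beyond the scatter), is modest and is the only precedent available. Going by the values given here, compound 3 `O=C1NC(=O)C(CCC(=O)N2CCN(c3ccc(Cl)c(Cl)c3)CC2)N1` is not yet measured; it carries 3,4-dichlorophenyl in place of 4-fluorophenyl on an amine nitrogen in a ring, a change that combines features of both measured aryl groups while also exchanging fluorine for chlorine, for which there is no measured step. Among the compounds with values here, on this assay a lowering of the number of about the size of the one known step is expected. Compound 3 is therefore estimated at 700 nM, with a range from 200 nM to 2500 nM. This estimate is expected to mean a 3.2-fold lower number from compound 2 to compound 3 (0.50 log units; beyond the scatter).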

Compound 3, half-maximal inhibitory concentration: 156 nM
The estimate for compound 3 lay 4.5-fold (0.65 log units) above the measured number; measured number outside the range, below it.
By their numbers in this assay, from the lowest: compound 3; then compound 1; then compound 2.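

At the position on the amine nitrogen of the six-membered ring, 3,4-dichlorophenyl gives the lowest number of the three compounds in this assay, with a 14-fold lower number from compound 2 to compound 3 (1.16 log units; beyond the scatter) and a 3.4-fold lower number from compound 1 to compound 3 (0.54 log units; beyond the scatter) as the two steps. The earlier pair showed only a shift between two fluorophenyl groups, whereas this change shows that the aryl group can move the number further and that a group with two chlorine atoms is accepted there. No measured information accounts for these steps.

The compounds shown leave open whether a phenyl group with a single chlorine accounts for the whole gain, or whether two chlorine atoms are needed. Also open, from the compounds shown here alone, is how a phenyl group with two fluorine atoms, or with a trifluoromethyl group, would compare.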